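Amino in Place of Hydroxy on a Fused Ring

The source may hold more compounds than are shown below. What is called first, only, known or untested is meant among the compounds shown, and "the series" means these compounds.

Measured so far:
compound 1, `N#CC1=C(N)Oc2c(ccc(N)c2N)C1c1cccc(C#N)c1` — 390000000 nM
compound 2, `COc1cc(C2C(C#N)=C(N)Oc3c2ccc(C)c3C)cc(Br)c1OC` — 46000000 nM
compound 3, `COc1cc(C2C(C#N)=C(N)Oc3cc(O)ccc32)cc(Br)c1OC` — 130000000 nM

In a functional assay on T47D cells (Homo sapiens) for activation (a higher number here means that more compound is needed for the effect, a lower number that less compound is needed), compound 3 gives 130000000 nM, the second highest of the three numbers. Compound 2 gives 46000000 nM, a lower number beyond the scatter, and compound 1 gives 390000000 nM, a higher number beyond the scatter. Compound 4, `COc1cc(C2C(C#N)=C(N)Oc3cc(N)ccc32)cc(Br)c1OC`, has not been measured. It differs from compound 3 in one place: amino in place of hydroxy on an aromatic carbon. Going by the values given here, no measured pair shows this exchange, so its effect is unknown here; compound 1, which carries amino groups, gives the highest number, but it differs in many places. Compound 4 is expected to stay close to compound 3, with a step of a 1.2-fold higher number from compound 3 to compound 4 (0.06 log units; within the scatter) in this assay that is not beyond the scatter. Compound 4 is estimated at 150000000 nM, within 50000000 nM to 450000000 nM.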

Compound 4, half-maximal effective concentration: 33000000 nM
Compound 4: middle estimate off by 4.5-fold (0.66 log units), on the high side; the whole stated range lies above it.
By their numbers in this assay, from the lowest: compounds 4 and 2 (each within the scatter of the next); then compound 3; then compound 1.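

On this aromatic carbon of the fused system, the exchange of hydroxy for amino is not silent: in this assay it gives a clear step (a 3.9-fold lower number from compound 3 to compound 4 (0.60 log units; beyond the scatter)). Going by these compounds alone, this is the first pair to isolate the position, and it shows that replacing one heavy atom, with the hydrogen-bond donor and acceptor counts unchanged, can move the number beyond the scatter. Nothing measured here explains this step. From the compounds shown here alone, whether an acetamide or a dimethylamino group on this carbon would lower the number further remains open, as does whether the step carries over to other cores.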